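The compounds below may be only part of what the source reports. "The series", "measured", "known", "first", "only" and "open" are said of these compounds alone.

Working notes on the series

The three measured compounds share one core and are read in a functional assay on PANC-1 cells (Homo sapiens) for inhibition, read by MTT assay, with a stated time of 24 h, tested at 10 uM; a higher number here means more inhibition at the concentration tested (going by the name of the read-out), a lower number less inhibition. Compound 3 `CC(C)=CCC/C(C)=C/CC1Cc2c(OCCCNC(=O)c3ccco3)cc(=O)n(CCCO)c2CC1(C)C` gives 2.8%. Compound 1 `CC(C)=CCC1Cc2c(OCCCOc3ccc([N+](=O)[O-])cc3)cc(=O)n(CCCO)c2CC1(C)C` gives 0%, and compound 2 `CC(C)=CCC/C(C)=C/CC1Cc2c(OCCCNS(=O)(=O)c3ccc(Br)cc3)cc(=O)n(CCCO)c2CC1(C)C` gives 0%. On these numbers compound 3 is the highest of the three, but its gaps to compound 1 and to compound 2 are both within the scatter, so no order among them can be read.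

For the measured compounds named here, the only step between neighbours that differ in one place is a number 2.8 percentage points higher from compound 2 to compound 3 (within the scatter), a change on the amine nitrogen of the side chain.

Compound 4 `CC(C)=CCC/C(C)=C/CC1Cc2c(OCCCOc3ccc([N+](=O)[O-])cc3)cc(=O)n(CCCO)c2CC1(C)C` is not yet measured. It differs from compound 3 by 4-nitrophenoxy in place of ((furan-2-yl)carbonyl)amino on a saturated chain carbon, three bonds along the chain from an oxygen on an aromatic ring. Going by the values given here, no measured step covers this exchange; compound 1 carries the same 4-nitrophenoxy end but on a different chain, and it gives 0%, while compound 3 gives 2.8%, the two within the scatter of each other. All three measured values sit near zero, so the expected step of a number 1.8 percentage points lower from compound 3 to compound 4 (within the scatter) is none beyond the scatter. Compound 4 is therefore estimated at 1%, within 0% to 10%.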

Compound 4, a percentage reported as inhibition, at one concentration (the size of the read-out at that concentration, not a potency): 9.8%
Compound 4: the middle estimate sits 8.8 percentage points below what was measured; low and high end bracket the measured number.
By their numbers in this assay, from the lowest: compounds 1, 2, 3 and 4 (each within the scatter of the next).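

In this assay, exchanges at the saturated chain carbon, three bonds along the chain from an oxygen on an aromatic ring, now cover two more end groups: 4-nitrophenoxy in place of ((furan-2-yl)carbonyl)amino gives a number 7 percentage points higher from compound 3 to compound 4 (within the scatter), and 4-nitrophenoxy in place of ((4-bromophenyl)sulfonyl)amino gives a number 9.8 percentage points higher from compound 2 to compound 4 (within the scatter), so neither exchange can be read as an effect. For the compounds shown here, the second chain is also reached for the first time: 3-methylbut-2-en-1-yl in place of hydrogen on a saturated chain carbon bound to a double-bonded chain carbon gives a number 9.8 percentage points higher from compound 1 to compound 4 (within the scatter), again with no readable effect. No measurement at hand bears on these results.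

Still open, from the compounds shown here alone, is whether a primary amine or a carboxylic acid at this chain end would give a step beyond the scatter. The same question stands for a longer chain carrying the 4-nitrophenoxy end.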